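The source may hold more compounds than are shown below. What is called first, only, known or untested is meant among the compounds shown, and "the series" means these compounds.

Measured compounds:
compound 1 `COc1cc2nc(N3CCN(S(=O)(=O)c4ccc(C)cc4)CC3)nc(N)c2cc1OC`, in a functional assay on PC-3 cells (Homo sapiens) for inhibition (on this read-out lower numbers stand for stronger inhibition and higher numbers for weaker inhibition), compound 1 gives 30000 nM
compound 2 `COc1cc2nc(N3CCN(S(=O)(=O)c4ccc(C(=O)O)cc4)CC3)nc(N)c2cc1OC`, in this assay compound 2 gives 53000 nM

Among the measured compounds shown here, compound 2 holds the higher of these two numbers; its only neighbour is compound 1, and a 1.8-fold higher number from compound 1 to compound 2 (0.25 log units; within the scatter) lies within the scatter. Compound 3 `COc1cc2nc(N3CCN(S(=O)(=O)c4cccc5ccccc45)CC3)nc(N)c2cc1OC` differs from compound 2 by naphthalen-1-yl in place of 4-carboxyphenyl on a sulfonyl sulfur. For the measured compounds named here, the single measured step, a 1.8-fold higher number from compound 1 to compound 2 (0.25 log units; within the scatter), swaps one substituent for another on an aromatic carbon and stays within the scatter, so it gives little guidance for replacing the whole 4-carboxyphenyl by naphthalen-1-yl. Compound 3 is expected to remain close to the measured numbers, a 2.1-fold lower number from compound 2 to compound 3 (0.33 log units; beyond the scatter) being the step this estimate means. The estimate for compound 3 is 25000 nM, with a range from 8000 nM to 80000 nM.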

Compound 3, half-maximal inhibitory concentration: 14000 nM
For compound 3 the middle estimate is 1.8-fold (0.25 log units) above the measured one; measured number inside the range.
By their numbers in this assay, from the lowest: compound 3; then compounds 1 and 2 (each within the scatter of the next).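

In this assay, replacing the whole aryl group on the sulfonyl sulfur moves the number beyond the scatter, which the swap of one substituent on the aromatic carbon did not do. Naphthalen-1-yl gives a 3.8-fold lower number from compound 2 to compound 3 (0.58 log units; beyond the scatter) in place of 4-carboxyphenyl and a 2.1-fold lower number from compound 1 to compound 3 (0.33 log units; beyond the scatter) in place of 4-methylphenyl , both modest steps in the same direction. Nothing available explains this gain. The compounds shown leave open whether a plain phenyl, an aminophenyl or a naphthalen-2-yl on the sulfonyl sulfur would match compound 3.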